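The source may report more compounds than this note shows. Statements on the series, on what has been measured and on what is new or still open speak of the compounds shown alone.

Compound 1, `CCOC(=O)CCCCCOc1cccc(CN(C(=O)c2ccc(-c3ccncc3)cc2)C(C)C)c1`, in an ADME assay on BJ cells (Homo sapiens) for cytotoxicity, read by CellTiter-Glo and resazurin assay, with a stated time of 72 h (a higher number here means that more compound is needed for the effect, a lower number that less compound is needed), gives only a limit: > 26000 nM.
Compound 2, `CCOC(=O)CCCCCOc1cccc(CN(C(=O)c2ccc(-c3cccc(OCC(C)C)c3)cc2)C(C)C)c1`, in this assay likewise gives only a limit: > 26000 nM.

Within the data shown here, compound 2 therefore stands at the edge of what this assay can read, with a limit rather than a number, and the one other value shown sits at that same limit (the limit of > 26000 nM in this assay, at which 2 of the 2 values shown sit). Compound 3, `CCOC(=O)CCCCCOc1cccc(CN(C(=O)c2ccc(-c3cccc(-c4nnc(C)o4)c3)cc2)C(C)C)c1`, has not yet been measured. It differs from compound 2 in one place: 5-methyl-1,3,4-oxadiazol-2-yl in place of isobutoxy on an aromatic carbon. Among the measured compounds shown here, the only measured step, a step that the two limits leave unreadable from compound 1 to compound 2, runs between two limits and cannot be sized; it offers no direction for the step into compound 3. With nothing pointing either way, the expected step that the limit leaves unreadable from compound 2 to compound 3 is none beyond the scatter. Compound 3 is expected most likely to return another limit. Compound 3 is estimated at 40000 nM, within a range from 15000 nM to 120000 nM.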

Compound 3, half-maximal effective concentration: > 26000 nM
Compound 3: only a limit was reported; the forecaster's own chance of this, stated with the estimate: 80%; the middle value does not contradict the limit.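

Among these compounds, compound 3, like compound 1 and compound 2, gives only a limit, so no step from compound 1 or compound 2 to compound 3 can be read: the limit of > 26000 nM in this assay, at which 3 of the 3 values shown sit. The compounds shown leave open what concentration of any of them would produce the effect in this assay, and whether isobutoxy and 5-methyl-1,3,4-oxadiazol-2-yl differ there at all.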